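Thiophen-2-yl in place of 2-phenylethenyl: working notes

A few compounds are considered here, and "the series" means these few. Any claim that something is new, unique, unknown or untested is made for them only; others in the source may bear on it.

Measured in an ADME assay on HEK293 cells (Homo sapiens) for inhibition, read by MTT assay, with a stated time of 48 h; a lower number here means a stronger inhibitor, a higher number a weaker inhibitor:
- compound 1 `C(=C/c1nc2ccccn2c1Sc1ccccc1)\c1ccccc1`: > 100000 nM (a limit)
- compound 2 `Cc1ccc(-c2nc3ccc(C)cn3c2Sc2ccccc2)cc1`: > 100000 nM (a limit)

Compound 1 gives no number in this assay, only the limit > 100000 nM. Among the measured compounds shown here, the series so far consists of the limit of > 100000 nM in this assay, at which 2 of the 2 values shown sit. For the measured compounds named here, no step between measured compounds is available, so the size of any change is unknown.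

Compound 3 `c1ccc(Sc2c(-c3cccs3)nc3ccccn23)cc1` carries thiophen-2-yl in place of 2-phenylethenyl on an aromatic carbon of the shared core: thiophen-2-yl in place of 2-phenylethenyl on an aromatic carbon.

In this assay no step beyond the usual scatter is expected, and a further limit is the likeliest reading. This expectation rests on compound 2, a limit at > 100000 nM. The estimated change is a number no higher from compound 1 to compound 3 (the limit leaves the size open). Compound 3 is estimated at 100000 nM, with an expected range of 40000 nM to 150000 nM.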

Compound 3, half-maximal inhibitory concentration: > 100000 nM
Compound 3: a limit, no number (the forecaster's own chance of this, stated with the estimate: 85%); the middle value sits exactly at the limit.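

Compound 1 and compound 3 both give only limits in this assay, so no step can be read for thiophen-2-yl in place of 2-phenylethenyl. The compounds shown leave open whether any compound in this series gives a readable number in this assay: the limit of > 100000 nM in this assay, at which 3 of the 3 values shown sit.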